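Replacing 3,5-dichloropyridin-4-yl with 2,6-dichlorophenyl

A few compounds are considered here, and "the series" means these few. Any claim that something is new, unique, unknown or untested is made for them only; others in the source may bear on it.

In an ADME assay on microsomes from liver (Mus musculus) for metabolic stability (on this read-out higher numbers stand for a longer-lived compound and lower numbers for a shorter-lived compound), compound 1 (`O=C(O)c1cc(F)c2nc(N3CCC4(C=C(c5c(-c6ccccc6OC(F)(F)F)noc5C5CC5)C4)CC3)sc2c1`) gives 1.52 h as its half-life. Compound 2 (`O=C(O)c1cc(F)c2nc(N3CCC4(C=C(c5c(-c6c(Cl)cncc6Cl)noc5C5CC5)C4)CC3)sc2c1`) reads > 2 h and this is a limit of the assay, not a number. Compound 3 (`O=C(O)c1cc(F)c2nc(N3CCC4(C=C(c5c(-c6c(Cl)cccc6Cl)noc5C5CC5)C4)CC3)sc2c1`) carries 2,6-dichlorophenyl in place of 3,5-dichloropyridin-4-yl on an aromatic carbon. Going by the values given here, the one measured change at this place is an at least 1.3-fold higher number from compound 1 to compound 2 (0.11 log units; that floor lies within the scatter) and that is only a floor, so no step beyond the scatter is expected here. The expected step in this assay is a number no higher from compound 2 to compound 3 (the limit leaves the size open) on present evidence. Compound 3 is estimated at 2 h with a likely range of 1.2 h to 3.3 h for its half-life.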

Compound 3, half-life: 2 h
Compound 3: middle estimate and measured number agree at the digits printed; measured number inside the range.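

In this assay, putting 2,6-dichlorophenyl in place of 2-(trifluoromethoxy)phenyl gives a 1.3-fold higher number from compound 1 to compound 3 (0.12 log units; within the scatter). This gives the change at this position a real size rather than only a floor, and that size does not go beyond the usual scatter. Putting 2,6-dichlorophenyl in place of 3,5-dichloropyridin-4-yl gives a number no higher from compound 2 to compound 3 (the limit leaves the size open). The size of this step cannot be read, because the value of compound 2 is a limit and not a number: the limit of > 2 h in this assay, at which 1 of the 3 values shown sits.

On these data alone, whether the ring nitrogen of 3,5-dichloropyridin-4-yl makes any difference to the half-life therefore stays open. Also open, as far as these compounds go, is how a plain phenyl or a 2,6-difluorophenyl group would read at this position.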